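Aryl swap on the saturated ring carbon of compound 1

This account rests on a few compounds, and the source may have more. Where it says the series, first, only, none or still open, it means among the compounds named here.

Compound 1 `COc1cc(C2=NN(C(C)=O)C(c3cccc(OC)c3OC)O2)cc(OC)c1OC` gives 35% in a functional assay on PC-3 cells (Homo sapiens) for antiproliferative activity, read by MTT assay, tested at 1 uM (on this read-out higher numbers stand for a stronger effect at the one concentration tested and lower numbers for a weaker effect), the highest of the two numbers at hand; compound 2 `COc1cc(/C=N/NC(=O)c2cc(OC)c(OC)c(OC)c2)cc(OC)c1OC` gives 8.5% in this assay, a gap beyond the usual scatter. Within the data shown here, no two measured compounds differ in a single place, so nothing here isolates a change of the aryl group. Compound 3 `COc1cc(C2=NN(C(C)=O)C(c3ccc(C(F)(F)F)cc3)O2)cc(OC)c1OC` differs from compound 1 by 4-(trifluoromethyl)phenyl in place of 2,3-dimethoxyphenyl on a saturated ring carbon. For this change a step of modest size in this assay is expected, in either direction, possibly none beyond the scatter. Compound 3 is therefore estimated at 30%, within 10% to 55%. The step expected is a number 5 percentage points lower from compound 1 to compound 3 (within the scatter).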

Compound 3, a percentage reported as inhibition, at one concentration (the size of the read-out at that concentration, not a potency): -11%
The estimate for compound 3 lay 41 percentage points above the measured number; the measured number lies below the stated range.
By their numbers in this assay, from the lowest: compound 3; then compound 2; then compound 1.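

In this assay, the aryl group on the saturated ring carbon clearly matters: 4-(trifluoromethyl)phenyl in place of 2,3-dimethoxyphenyl gives a number 46 percentage points lower from compound 1 to compound 3 (beyond the scatter). Among these compounds, this is the only single-place comparison, and it shows that the shared core alone does not set the read-out. No measurement available bears on the reason for this step.

Still open, as far as these compounds go, is whether the drop follows the loss of the two methoxy groups or the arrival of trifluoromethyl, as the two changes come together here. An unsubstituted phenyl or a phenyl with a single methoxy group would separate these two changes.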